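The compounds below may be only part of what the source reports. "The series", "measured", "known", "first", "only" and "open" are said of these compounds alone.

Measured so far:
- compound 1 `COc1ccc2[nH]c(C(=O)N3CC(=O)N(Cc4ccccc4)[C@@H](CN4CCC(OC)CC4)C3)cc2c1`, in a physicochemical assay for solubility, read by spectrophotometry, in phosphate buffer, with a stated time of 2 h, at pH 7.4 (a lower number here means a less soluble compound, a higher number a more soluble compound), compound 1 gives > 25000 nM
- compound 2 `COc1ccc2[nH]c(C(=O)N3CC(=O)N(Cc4ccc[nH]4)[C@@H](Cc4ccccc4)C3)cc2c1`, in this assay compound 2 gives 38400 nM.

Compound 1 is the one whose figure is a limit of the assay, not a number; the reading stops at the limit of > 25000 nM in this assay, at which 1 of the 2 values shown sits, so compound 1 stands at or beyond the top of what was resolved. For the measured compounds named here, compound 2 returns an actual value, and no single-point step between compound 1 and compound 2 is drawn, so the pair shows only that both sit in the high range of this assay.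

Compound 3 `COc1ccc2[nH]c(C(=O)N3CC(=O)N(Cc4ccccc4)[C@@H](CN4CC5CCCC5C4)C3)cc2c1` is the untested member. Against compound 1 the change is a group of 8 heavy atoms (7 carbon, 1 nitrogen; one five-membered non-aromatic ring of carbon only, one five-membered non-aromatic ring with 1 hetero atom) in place of a group of 8 heavy atoms (6 carbon, 1 nitrogen, 1 oxygen; one six-membered non-aromatic ring with 1 hetero atom), on a saturated chain carbon bound to a saturated ring carbon. The 4-methoxypiperidin-1-yl group leaves and an oxygen-free bicyclic amine of the same heavy-atom count enters, on a saturated chain carbon bound to a saturated ring carbon.

With compound 1 known only as a limit, the step cannot be anchored from above. The expectation is a downward move in solubility, of a size near or a little beyond the scatter, expressed as an at least 1.6-fold lower number from compound 1 to compound 3 (0.22 log units; that floor lies within the scatter). Compound 3 is therefore estimated at 15000 nM, with a range from 5000 nM to 45000 nM.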

Compound 3, solubility: 20700 nM
Estimate against measurement, compound 3: 1.4-fold (0.14 log units) below; the measured number falls inside the stated range.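

In this assay, for the compounds shown here, compound 3 gives 20700 nM, which is the first resolved number for a tertiary bicyclic amine on this saturated chain carbon bound to a saturated ring carbon; the earlier compounds gave no resolved value for an amine at this place. Compound 1 remains a limit of the assay, not a number: the limit of > 25000 nM in this assay, at which 1 of the 3 values shown sits. Replacing the 4-methoxypiperidin-1-yl group with the oxygen-free bicyclic amine of equal heavy-atom count therefore gives only a floor for the step, an at least 1.2-fold lower number from compound 1 to compound 3 (0.08 log units; that floor lies within the scatter), so its true size could lie within the usual scatter or beyond it.

The single step changes the ether oxygen and the ring system together, and the compounds shown do not separate the two. Plain piperidin-1-yl and morpholin-4-yl on the same carbon, set against the benzyl-bearing core of compound 1, would each offer a comparison that pulls these two changes apart, provided their values are resolved rather than limits.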